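A Benzyl for an Alkyne: Predicting Compound 4

The source may hold more compounds than are shown below. What is called first, only, known or untested is meant among the compounds shown, and "the series" means these compounds.

Three compounds built on a shared core were measured in a physicochemical assay for lipophilicity; on this read-out higher numbers stand for higher lipophilicity and lower numbers for lower lipophilicity. Compound 1 `CC#CCn1c(N2CCC[C@@H](N)C2)cc(=O)n(Cc2cc(C)cc(C)c2)c1=O` gives 2.78 in this assay. Compound 2 `Cc1cc(C)cc(Cn2c(=O)cc(N3CCC[C@@H](N)C3)n(Cc3cc(F)ccc3C#N)c2=O)c1` carries 2-cyano-5-fluorophenyl in place of prop-1-yn-1-yl on a saturated chain carbon bound to an aromatic nitrogen, and the step is a number 1.11 log units higher from compound 1 to compound 2 (beyond the scatter). In this assay compound 2 gives 3.89. Compound 3 `CC#CCn1c(N2CCC[C@@H](N)C2)cc(=O)n(CCCCCC)c1=O` has a different core from compound 1, the difference being (pentyl in place of 3,5-dimethylphenyl on a saturated chain carbon bound to an aromatic nitrogen); the step is a number 0.63 log units lower from compound 1 to compound 3 (beyond the scatter). In this assay compound 3 gives 2.15, the lowest of the three numbers.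

Compound 4 `CCCCCCn1c(=O)cc(N2CCC[C@@H](N)C2)n(Cc2cc(F)ccc2C#N)c1=O` has not yet been measured. It differs from compound 3 by 2-cyano-5-fluorophenyl in place of prop-1-yn-1-yl on a saturated chain carbon bound to an aromatic nitrogen. Among the compounds with values here, this is the same change as the one from compound 1 to compound 2, at the same place, now made on the core of compound 3 rather than the core of compound 1. Within the data shown here, the only guide to its size is that single earlier pair. Because the step of a number 1.11 log units higher from compound 1 to compound 2 (beyond the scatter) was large and beyond the scatter, a step of similar size is expected here: the account expects a number 1.11 log units higher from compound 3 to compound 4 (beyond the scatter). Whether the different core of compound 3 alters the size of this step cannot be told from the data. Compound 4 is therefore estimated to give 3.26 in this assay, with the expected range running from 2.9 to 3.62.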

Compound 4, partition coefficient: 3.26
Compound 4: the middle estimate sits on the measured number at the digits printed, within the range that was stated.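

In this assay, putting 2-cyano-5-fluorobenzyl in place of but-2-yn-1-yl on the core of compound 3 gives a number 1.11 log units higher from compound 3 to compound 4 (beyond the scatter), and this step matches a number 1.11 log units higher from compound 1 to compound 2 (beyond the scatter), so the change carries over from the core of compound 1 to the core of compound 3 with its size intact. The four compounds also close a square: pentyl in place of 3,5-dimethylphenyl gives a number 0.63 log units lower from compound 2 to compound 4 (beyond the scatter), which matches a number 0.63 log units lower from compound 1 to compound 3 (beyond the scatter), so in these compounds the two changes simply add, with no sign that either alters the size of the other. This is one square of four compounds, however, and it does not show that the step would keep its size on any further core, while nothing measured here speaks to what lies behind that size.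

The compounds shown leave open whether the two changes would still add if the group at this place carried an amine or a carboxylic acid, or if the pentyl gave way to a longer chain. They also leave open whether a read-out other than this assay would show the same agreement between the two cores.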